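The compounds below may be only part of what the source reports. "The series", "measured", "known", "first", "only" and "open" are said of these compounds alone.

Working notes on the series. Compound 1 `CC(C)OC(=O)N1CCC(Oc2ncnc3c2CCN3c2ccc(C#N)cc2F)CC1` serves as the reference; in a functional assay on CHO-K1 cells for agonist activity at Glucose-dependent insulinotropic receptor (Homo sapiens), read by a luciferase reporter, with a stated time of 5 h (a higher number here means that more compound is needed for the effect, a lower number that less compound is needed), compound 1 gives 63.1 nM. Compound 2 `CC(C)OC(=O)N1CCC(Oc2ncnc3c2CCN3c2ccc(S(C)(=O)=O)cn2)CC1` gives 126 nM in this assay, and compound 3 `CC(C)OC(=O)N1CCC(Oc2ncnc3c2CCN3c2ccc(S(C)(=O)=O)nc2)CC1` gives 251 nM. Among the compounds with values here, compound 3 stands at the highest number of the three measured so far: the step of a 4.0-fold higher number from compound 1 to compound 3 (0.60 log units; beyond the scatter) is modest but beyond the scatter, whereas a 2.0-fold higher number from compound 2 to compound 3 (0.30 log units; within the scatter) remains within it, as does a 2.0-fold higher number from compound 1 to compound 2 (0.30 log units; within the scatter).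

The next step leads from compound 3 to compound 4 `CC(C)OC(=O)N1CCC(Oc2ncnc3c2CCN3c2ccc(C#N)cn2)CC1`: 5-cyanopyridin-2-yl in place of 6-(methylsulfonyl)pyridin-3-yl on a nitrogen on an aromatic ring in a ring. Compound 4 therefore shares the cyano substituent with compound 1 and the pyridin-2-yl attachment with compound 2. Within the data shown here, two measured steps bear on this change. The step of a 4.0-fold higher number from compound 1 to compound 3 (0.60 log units; beyond the scatter) covers the loss of the cyano group together with the change of the attached ring; the step of a 2.0-fold higher number from compound 2 to compound 3 (0.30 log units; within the scatter) covers the change of attachment alone. Undoing both points to a modest move toward a lower number in this assay, though no measured compound combines a cyano group with a pyridin-2-yl attachment, so the size remains uncertain. The step expected to compound 4 is a 3.1-fold lower number from compound 3 to compound 4 (0.50 log units; beyond the scatter). Compound 4 is estimated at 80 nM, with a range from 30 nM to 250 nM.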

Compound 4, half-maximal effective concentration: 794 nM
Compound 4: the middle estimate sits 9.9-fold (1.00 log units) below what was measured; measured number outside the range, above it.
By their numbers in this assay, from the lowest: compounds 1, 2 and 3 (each within the scatter of the next, the first and the last beyond it); then compound 4.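

Within the data shown here, at the nitrogen position on the shared core, 5-cyanopyridin-2-yl offers no gain over the sulfone-bearing pyridine: the exchange gives a 3.2-fold higher number from compound 3 to compound 4 (0.50 log units; beyond the scatter) in this assay and makes compound 4 the highest number of the series so far. Among these compounds, with the pyridin-2-yl attachment held constant, cyano in place of methylsulfonyl on an aromatic carbon gives a 6.3-fold higher number from compound 2 to compound 4 (0.80 log units; beyond the scatter) and provides the first reading of these two substituents on the same ring, with methylsulfonyl giving the lower number. Among the compounds shown here, the comparison with the reference gives a 13-fold higher number from compound 1 to compound 4 (1.10 log units; beyond the scatter) and is the first large step, so a cyano group does not by itself confer the low number of compound 1, and the result depends on the ring that carries it.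

The compounds shown leave open whether the gap between compound 1 and compound 4 follows the ring nitrogen or the fluoro substituent, a question that a plain 4-cyanophenyl group at the same place would help to separate. No available measurement accounts for the reversal seen with the cyano group on the pyridine ring.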